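Second methoxy on the aryl ring of compound 1

This account rests on a few compounds, and the source may have more. Where it says the series, first, only, none or still open, it means among the compounds named here.

Measured so far:
compound 1 `COc1ccc([C@]2(CO)NC[C@@H](O)[C@@H]2O)cc1`: 40.2%
compound 2 `OC[C@]1(c2c(F)c(F)c(F)c(F)c2F)NC[C@H](O)[C@H]1O`: 6.9%
compound 3 `Cc1ccc([C@]2(CO)NC[C@@H](O)[C@@H]2O)cc1`: 21.3%

In an assay on isolated protein for inhibition of lysosomal alpha-glucosidase (Homo sapiens), tested at 1000 uM (a lower number here means less inhibition, a higher number more inhibition at the concentration tested (going by the name of the read-out)), compound 1 gives the highest of the three numbers. Among the compounds with values here, compound 3 comes nearest, and the one measured step, a number 18.9 percentage points lower from compound 1 to compound 3 (beyond the scatter), is beyond the scatter. Compound 2 lies furthest off, its value standing well below that of compound 1.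

Compound 4 `COc1ccc([C@]2(CO)NC[C@@H](O)[C@@H]2O)cc1OC` differs from compound 1 in one place: methoxy in place of hydrogen on an aromatic carbon. Within the data shown here, no measured step touches this change. The step to compound 3 swaps the methoxy for a methyl; the gap to compound 2 replaces the whole aryl substitution pattern. Neither tells how a second methoxy on the same ring will act. The methoxy-bearing compound 1 is the best of the set, so a drop is not expected to be large; the expected step of a number 2.2 percentage points lower from compound 1 to compound 4 (within the scatter) is therefore estimated as none beyond the scatter, with a wide range to either side. For compound 4 the estimate in this assay is 38%, between 20% and 55%.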

Compound 4, a percentage reported as inhibition, at one concentration (the size of the read-out at that concentration, not a potency): 11.1%
For compound 4 the middle estimate is 26.9 percentage points above the measured one, outside the stated range (below it).
By their numbers in this assay, from the lowest: compounds 2 and 4 (each within the scatter of the next); then compound 3; then compound 1.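

In this assay, adding a methoxy to the aromatic carbon ortho to a methoxy group and meta to a group of 9 heavy atoms gives a number 29.1 percentage points lower from compound 1 to compound 4 (beyond the scatter). The earlier step changed only the existing methoxy, to methyl; this one shows that a ring carbon bearing hydrogen in compound 1 does not take a methoxy without a loss of inhibition. In this pair, a second methoxy on the ring does not add to the inhibition seen with one. Nothing available bears on the reason for this loss.

A hydroxyl or an amine on this same carbon would show whether the loss goes with methoxy or with any group there. Also open, on these data alone, is whether the new methoxy lowers inhibition when the first methoxy is replaced by hydrogen.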